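The compounds below may be only part of what the source reports. "The series", "measured", "known", "first", "only" and "open" are said of these compounds alone.

Measured compounds:
- compound 1 `Cc1cc(C)cc(SCc2ccc(/C=C/C(=O)Nc3ccccc3N)cc2)c1`: 7.98%
- compound 2 `Nc1ccccc1NC(=O)c1ccc(CSc2cccc(F)c2)cc1`: 5.5%
- compound 3 `Nc1ccccc1NC(=O)c1ccc(CSc2ccc(C(F)(F)F)cn2)cc1`: 1.2%

In a functional assay on HCT-116 cells (Homo sapiens) for inhibition, read by CCK-8 assay, with a stated time of 72 h, tested at 2 uM (on this read-out lower numbers stand for less inhibition of growth and higher numbers for more inhibition of growth at the one concentration tested), compound 1 gives the highest of the three figures, yet compound 2 and compound 3 both sit within the usual scatter of it, so the three are not separated. All three are weak at the single concentration tested.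

Compound 4 `CC(C)(C)c1ccc(SCc2ccc(/C=C/C(=O)Nc3ccccc3N)cc2)cc1` is the next member. Against compound 1 the change is 4-(tert-butyl)phenyl in place of 3,5-dimethylphenyl on a sulfur.

Among the measured compounds shown here, no step between two measured compounds is available to size this change. With compound 1 at 7.98% and nothing in the set moving beyond the scatter, the step from compound 1 to compound 4 is expected to be small, most likely none beyond the scatter, with at best a slight rise: a number 2 percentage points higher from compound 1 to compound 4 (within the scatter). Compound 4 is therefore estimated at 10%, between 0% and 25%.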

Compound 4, percent growth inhibition at one concentration: 6.66%
Compound 4: middle estimate off by 3.3 percentage points, on the high side; low and high end bracket the measured number.
By their numbers in this assay, from the lowest: compounds 3, 2, 4 and 1 (each within the scatter of the next).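

The first step read at this position is a number 1.3 percentage points lower from compound 1 to compound 4 (within the scatter) in this assay. Exchanging 3,5-dimethylphenyl for 4-(tert-butyl)phenyl on a sulfur therefore leaves the two compounds unseparated, and both remain weak at the one concentration tested. Nothing available explains this outcome.

Still open, going by these compounds, is whether an amine or a carboxylic acid on the ring, or a longer chain in place of the ring, would move the figure beyond the scatter. Also open, on these data alone, is whether these compounds separate at other concentrations.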